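The compounds below may be only part of what the source reports. "The series", "measured", "known", "first", "only" and "open" are said of these compounds alone.

Measured so far:
compound 1 `O=C1COc2ccc(-c3cnc(Cl)c(NS(=O)(=O)c4ccc(F)cc4)c3)cc2N1c1ccc(F)cc1`: 32600 nM
compound 2 `CC(C)N1C(=O)COc2ccc(-c3cnc(Cl)c(NS(=O)(=O)c4ccc(F)cc4)c3)cc21`: 26600 nM

In a functional assay on MCF7 cells (Homo sapiens) for antiproliferative activity, read by MTT assay, with a stated time of 72 h (on this read-out higher numbers stand for weaker inhibition and lower numbers for stronger inhibition), compound 1 gives 32600 nM and compound 2 gives 26600 nM. Compound 2 carries the lowest of the two numbers shown, its nearest neighbour being compound 1, yet the step of a 1.2-fold lower number from compound 1 to compound 2 (0.09 log units; within the scatter) is within the scatter, so the two cannot truly be ranked. Compound 3 `Cc1ccc(N2C(=O)COc3ccc(-c4cnc(Cl)c(NS(=O)(=O)c5ccc(F)cc5)c4)cc32)cc1` differs from compound 2 by 4-methylphenyl in place of isopropyl on an amide-type nitrogen in a ring. Among the compounds with values here, the single measured step touching this position is a 1.2-fold lower number from compound 1 to compound 2 (0.09 log units; within the scatter), in which 4-fluorophenyl gave way to isopropyl on that nitrogen with no shift beyond the scatter. Since 4-methylphenyl, like the earlier 4-fluorophenyl, is a six-membered aromatic ring of carbon only, the return to such a group is expected to change little. Compound 3 is therefore estimated at 30000 nM, with a range from 15000 nM to 60000 nM. This amounts to an expected step of a 1.1-fold higher number from compound 2 to compound 3 (0.05 log units; within the scatter).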

Compound 3, half-maximal inhibitory concentration: 32600 nM
Estimate against measurement, compound 3: 1.1-fold (0.04 log units) below; low and high end bracket the measured number.
By their numbers in this assay, from the lowest: compounds 2, 1 and 3 (each within the scatter of the next).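

In this assay, placing 4-methylphenyl in place of isopropyl on the amide-type nitrogen gives a 1.2-fold higher number from compound 2 to compound 3 (0.09 log units; within the scatter), so across these compounds an aromatic ring and isopropyl on this nitrogen cannot be told apart. Swapping fluoro for methyl on that aromatic ring gives no change at the digits printed from compound 1 to compound 3 (within the scatter), so this substituent on the ring also shows no effect that can be read, adding a second kind of change at this position to the first. No supporting measurement here offers an explanation for these results.

Still open, on these data alone, is whether a different kind of group on this nitrogen, such as the plain amide hydrogen, a longer chain ending in an amine, or a carboxylic acid, would move the number beyond the scatter. All three compounds also share the rest of the core, so they say nothing about changes elsewhere in it.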